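Octylsulfanyl in place of propoxy in a sialidase-3 series

The source may hold more compounds than are shown below. What is called first, only, known or untested is meant among the compounds shown, and "the series" means these compounds.

Measured compounds:
Compound 1, `CCS[C@]1(C(=O)O)C=C[C@@H](NC(C)=O)[C@H]([C@H](O)[C@H](O)CO)O1`. In an assay on HEK293 cells for inhibition of sialidase-3 (Homo sapiens), read by fluorescence, with a stated time of 1 h (on this read-out higher numbers stand for weaker inhibition and lower numbers for stronger inhibition), compound 1 gives > 1000000 nM, which is a limit of the assay and not a number.
Compound 2, `CCS[C@@]1(C(=O)O)C=C[C@@H](NC(C)=O)[C@H]([C@H](O)[C@H](O)CO)O1`. In this assay compound 2 gives > 1000000 nM, also a limit.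
Compound 3, `CCCO[C@@]1(C(=O)O)C=C[C@@H](NC(C)=O)[C@H]([C@H](O)[C@H](O)CO)O1`. In this assay compound 3 gives > 1000000 nM, again a limit.

Compound 3 therefore stands at the limit, as do all values shown so far (the limit of > 1000000 nM in this assay, at which 3 of the 3 values shown sit). The step that the two limits leave unreadable from compound 1 to compound 2 cannot be read, the two compounds differing only in configuration (the fact that compounds 1 and 2 differ only in the configuration as drawn). The step that the two limits leave unreadable from compound 2 to compound 3 cannot be read either. Neither gives a size to lean on.

Compound 4, `CCCCCCCCS[C@@]1(C(=O)O)C=C[C@@H](NC(C)=O)[C@H]([C@H](O)[C@H](O)CO)O1`, is not yet measured. It differs from compound 3 by octylsulfanyl in place of propoxy on a saturated ring carbon. No measured step bears readably on this change, since both steps shown are hidden by the limit. The expected step is a number no higher from compound 3 to compound 4 (the limit leaves the size open), with nothing to suggest a move beyond the scatter. The estimate for compound 4 in this assay is 1000000 nM, with a range from 200000 nM to 5000000 nM, and the result is expected most likely to be reported once more as a limit.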

Compound 4, half-maximal inhibitory concentration: > 1000000 nM
Compound 4: only a limit was reported; the forecaster's own chance of this, stated with the estimate: 80%; the middle value lies on the limit itself.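

In this assay, within the data shown here, compound 4 gives > 1000000 nM, which is a limit and not a number, so no step from compound 2 or compound 3 to compound 4 can be read. The compounds shown leave open whether chain length, the ring-carbon substituent or configuration alters inhibition at all, with every value at the same limit: the limit of > 1000000 nM in this assay, at which 4 of the 4 values shown sit.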